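This account rests on a few compounds, and the source may have more. Where it says the series, first, only, none or still open, it means among the compounds named here.

In an ADME assay on L02 cells (Homo sapiens) for antiproliferative activity, read by CCK-8 assay, with a stated time of 6 days (a higher number here means a weaker inhibitor, a lower number a stronger inhibitor), compound 1 `CCN(c1ccc(C#N)c(Cl)c1)c1cc(-c2ccco2)ccc1C` gives "not determined" (no result reported) and compound 2 `CCN(c1ccc(C#N)c(Cl)c1)c1cc(-c2ccc(F)nc2)ccc1C` gives "not determined" (no result reported) while compound 3 `CCN(c1ccc(C#N)c(Cl)c1)c1cc(-c2c[nH]nc2C)ccc1C` gives 5780 nM. For the measured compounds named here, the only number therefore belongs to compound 3. Going by the values given here, with no second value, compound 3 cannot be ranked against anything, and no measured step shows how far a change of this group moves this assay.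

Compound 4 `CCN(c1ccc(C#N)c(Cl)c1)c1cc(-c2cccnc2)ccc1C` is still to be measured. It differs from compound 3 at one place, with pyridin-3-yl in place of 3-methyl-1H-pyrazol-4-yl on an aromatic carbon. Nothing measured points in either direction, so no shift beyond the usual scatter is expected, and the estimate rests on compound 3 at 5780 nM as the only anchor. The expected change, a 1.2-fold lower number from compound 3 to compound 4 (0.06 log units; within the scatter), is small, and its sign is uncertain. The estimated value for compound 4 is 5000 nM, with an expected range of 2000 nM to 12500 nM.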

Compound 4, half-maximal inhibitory concentration: 12700 nM
The estimate for compound 4 lay 2.5-fold (0.40 log units) below the measured number, outside the stated range (above it).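

For the compounds shown here, the first readable step at this position, on an aromatic carbon para to a methyl group, shows that this assay responds to the identity of the attached ring: pyridin-3-yl in place of 3-methyl-1H-pyrazol-4-yl gives a 2.2-fold higher number from compound 3 to compound 4 (0.34 log units; beyond the scatter). The heavy-atom count stays at 6, but the ring changes from five-membered with 2 hetero atoms to six-membered with 1, and the hydrogen-bond donor count falls from 1 to 0, so this single step does not separate these differences. No measurement at hand accounts for the shift.

Compound 1 and compound 2 give no number, so steps involving them cannot be read. Also open, going by these compounds, is whether an amine or a carboxylic acid carried on the pyridin-3-yl would move the number towards compound 3 or further away.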